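The source may hold more compounds than are shown below. What is called first, only, known or untested is meant among the compounds shown, and "the series" means these compounds.

Measured compounds, with their values in a functional assay on M14 cells (Homo sapiens) for inhibition, read by sulforhodamine B assay, with a stated time of 48 h; on this read-out higher numbers stand for weaker inhibition of growth and lower numbers for stronger inhibition of growth:

compound 1, `COc1cc(-c2nn(-c3cccc(NC(=O)Nc4cc(C(F)(F)F)cc(C(F)(F)F)c4)c3)cc2-c2ccncc2)ccc1Cl`, gives 808 nM
compound 2, `O=C(Nc1cccc(-n2cc(-c3ccncc3)c(-c3ccc(Cl)c(O)c3)n2)c1)Nc1cc(C(F)(F)F)cc(C(F)(F)F)c1`, gives 607 nM
compound 3, `COc1cc(-c2nn(-c3cccc(NC(=O)Nc4ccc(Cl)c(C(F)(F)F)c4)c3)cc2-c2ccncc2)ccc1Cl`, gives 1080 nM

All three share a urea-linked pyrazole scaffold and differ only at two edges of it. Compound 1 and compound 3 carry different aryl groups on the far side of the urea; the difference between the two cores is not broken down here. Their values in this assay lie within the scatter of one another, as do those of compound 2 and compound 3, so no order among the three can be claimed.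

Between compound 1 and compound 2 the change is hydrogen in place of methyl on an oxygen on an aromatic ring. In this assay this gave a 1.3-fold lower number from compound 1 to compound 2 (0.12 log units; within the scatter), a step that does not rise above the scatter.

Compound 4, `O=C(Nc1cccc(-n2cc(-c3ccncc3)c(-c3ccc(Cl)c(O)c3)n2)c1)Nc1ccc(Cl)c(C(F)(F)F)c1`, has not yet been measured. It stands to compound 3 as compound 2 stands to compound 1: the change is hydrogen in place of methyl on an oxygen on an aromatic ring, the same change at the same place, made on the core of compound 3 rather than that of compound 1.

For the measured compounds named here, with only one prior instance of this change, and that one within the scatter, the expectation for compound 4 rests on compound 3 staying roughly where it is. The step from compound 3 to compound 4 in this assay is estimated at a 1.3-fold lower number from compound 3 to compound 4 (0.10 log units; within the scatter), following the direction of the change from compound 1 to compound 2. Compound 4 is therefore expected to give about 850 nM, with a plausible range from 400 nM to 1800 nM.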

Compound 4, concentration for 50% growth inhibition: 886 nM
For compound 4 the middle estimate is 1.0-fold (0.02 log units) below the measured one, and the stated range covers the measured number.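

In this assay, going from methoxy to hydroxy on the 4-chloro-3-methoxyphenyl group gave a 1.2-fold lower number from compound 3 to compound 4 (0.09 log units; within the scatter). Set beside the earlier instance of this change, the two steps agree: the same change on two cores in this assay, a 1.3-fold lower number (0.12 log units; within the scatter) from compound 1 to compound 2 and a 1.2-fold lower number (0.09 log units; within the scatter) from compound 3 to compound 4, 1.1-fold (0.04 log units) apart, within the scatter of two such steps. On the two cores shown, then, hydrogen in place of methyl on this oxygen gives no step that rises above the scatter, and that absence of a readable step carries from one far-side aryl group on the urea to the other; it does not show that the hydroxy compounds differ from their methoxy partners, the shared direction of two steps within the scatter is no trend, and two cores say nothing about a core outside this set.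

Still open, from the compounds shown here alone, is whether a larger replacement at this place, such as an amine or a carboxylic acid in place of the hydroxy, or a chain longer than methyl on the oxygen, would give a step beyond the scatter. Also open, going by these compounds, is whether the agreement between the two cores would hold with a far-side aryl group carrying neither trifluoromethyl nor chlorine, for instance one bearing an amine.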